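The source may report more compounds than this note shows. Statements on the series, on what has been measured and on what is new or still open speak of the compounds shown alone.

Compound 1 `O=C(CC(=O)c1ccccc1O)c1cc2ccccc2s1`: 7.86 ug/mL
Compound 2 `O=C(CC(=O)c1cc(Cl)ccc1O)c1cc2ccccc2s1`: 4.42 ug/mL
Compound 3 `Cc1cc(O)c(C(=O)CC(=O)c2cc3ccccc3s2)cc1Cl`: > 100 ug/mL

In an ADME assay on HeLa cells (Homo sapiens) for inhibition, read by MTT assay, with a stated time of 72 h (on this read-out higher numbers stand for weaker inhibition of growth and lower numbers for stronger inhibition of growth), compound 2 gives the lowest of the two numbers, with compound 1 nearest at 7.86 ug/mL, a gap within the scatter. Compound 3 gives only a limit in this assay, > 100 ug/mL. Compound 4 `O=C(CC(=O)c1cc(Cl)cc(Cl)c1O)c1cc2ccccc2s1` differs from compound 2 by chloro in place of hydrogen on an aromatic carbon. Within the data shown here, two measured steps bear on it. The same kind of change gave a 1.8-fold lower number from compound 1 to compound 2 (0.25 log units; within the scatter), a step within the scatter. A different substitution on the same ring gave an at least 22-fold higher number from compound 2 to compound 3 (1.35 log units; beyond the scatter), a large loss. The change in compound 4 repeats the first kind, so in this assay a small step or none beyond the scatter is expected, with the estimate a 1.3-fold lower number from compound 2 to compound 4 (0.10 log units; within the scatter). Compound 4 is therefore expected to give 3.5 ug/mL, in the range 1.2 ug/mL to 12 ug/mL.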

Compound 4, concentration for 50% growth inhibition: > 100 ug/mL
Compound 4 was reported as a limit; the forecaster's own chance of this, stated with the estimate: 10%; at least 28-fold (1.45 log units) between middle value and limit.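

In this assay, chloro in place of hydrogen ortho to a hydroxy group gives an at least 22-fold higher number from compound 2 to compound 4 (1.35 log units; beyond the scatter), whereas the same kind of change elsewhere on that ring gave a 1.8-fold lower number from compound 1 to compound 2 (0.25 log units; within the scatter). The outcome of adding chloro therefore depends on its place on this ring, at least across these compounds. The value of compound 4 is a limit, so the true size of this step stays unknown: the limit of > 100 ug/mL in this assay, at which 2 of the 4 values shown sit.

Still open, on these data alone, is whether an amine or a methoxy group at this position would keep the growth inhibition of compound 2. Also open, as far as these compounds go, is whether chloro here gives the same loss without the second chloro group meta to it.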